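Swapping an Acetylpyrazole for a Pyridine Ring

The source may report more compounds than this note shows. Statements on the series, on what has been measured and on what is new or still open speak of the compounds shown alone.

Compound 2 `CNC(=O)N1CCCc2ccc(NC(=O)c3ccc(-c4ccn(C(C)=O)n4)cc3)cc21` gives 35.8% in a functional assay on MV4-11 cells (Homo sapiens) for antiproliferative activity, with a stated time of 6 days, tested at 1.56 uM (on this read-out higher numbers stand for a stronger effect at the one concentration tested and lower numbers for a weaker effect), the higher of the two measured numbers. Going by the values given here, compound 1 `CNC(=O)N1CCCc2ccc(NC(=O)c3ccc(-c4ccccc4)cc3)cc21` gives 19.7% in this assay, and the single measured step, a number 16.1 percentage points higher from compound 1 to compound 2 (beyond the scatter), is the only guide available. Compound 3 `CNC(=O)N1CCCc2ccc(NC(=O)c3ccc(-c4ccncc4)cc3)cc21` carries pyridin-4-yl in place of 1-acetyl-1H-pyrazol-3-yl on an aromatic carbon on an aromatic carbon, para to a large group. Pyridin-4-yl is a six-membered aromatic ring like phenyl, and compound 1 with phenyl gave 19.7%, so compound 3 is expected to land partway back with an estimated step of a number 8.8 percentage points lower from compound 2 to compound 3 (within the scatter). Compound 3 is therefore estimated at 27%, within a range from 10% to 45%.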

Compound 3, a percentage reported as inhibition, at one concentration (the size of the read-out at that concentration, not a potency): 37.6%
Compound 3: middle estimate off by 10.6 percentage points, on the low side, and the stated range covers the measured number.
By their numbers in this assay, from the lowest: compound 1; then compounds 2 and 3 (each within the scatter of the next).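

In this assay, at this aromatic carbon para to a large group, pyridin-4-yl in place of phenyl gives a number 17.9 percentage points higher from compound 1 to compound 3 (beyond the scatter), while pyridin-4-yl in place of 1-acetyl-1H-pyrazol-3-yl gives a number 1.8 percentage points higher from compound 2 to compound 3 (within the scatter). So the rise over phenyl is not tied to the five-membered ring or its acetyl group: a six-membered ring with one ring nitrogen reaches the same level.

Going by these compounds, whether pyridin-3-yl, with the ring nitrogen moved, or an amine such as piperazin-1-yl would keep this level remains open. No evidence at hand explains either step.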